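This account rests on a few compounds, and the source may have more. Where it says the series, first, only, none or still open, it means among the compounds named here.

Measured compounds:

Compound 1 `CCOc1ccc(CN(Cc2ccc(C(C)(C)C)cc2)Cc2cc3cc(C)ccc3[nH]c2=O)cc1` in a toxicity assay on MDCK cells (Canis lupus familiaris) for cytotoxicity, read by crystal violet staining, with a stated time of 48 h (a higher number here means that more compound is tolerated, a lower number that less compound is tolerated), gives > 10000 nM, which is a limit of the assay and not a number.
Compound 2 `Cc1ccc2[nH]c(=O)c(CN(Cc3ccc(N(C)C)cc3)Cc3ccc(C(C)(C)C)cc3)cc2c1` in this assay gives > 5000 nM, again a limit rather than a number.
Compound 3 `Cc1ccc2[nH]c(=O)c(CN(Cc3ccc(C#N)cc3)Cc3ccc(C(C)(C)C)cc3)cc2c1` in this assay gives > 5000 nM, also a limit and not a number.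

Compound 3 therefore stands at a limit, and the two other values shown are limits as well: one sits at the limit of > 10000 nM in this assay, at which 1 of the 3 values shown sits, and two sit at the limit of > 5000 nM in this assay, at which 2 of the 3 values shown sit. Among the compounds with values here, none of the measured steps can be read in size: a step that the two limits leave unreadable from compound 1 to compound 2, a step that the two limits leave unreadable from compound 1 to compound 3 and a step that the two limits leave unreadable from compound 2 to compound 3 are all hidden by the limits on both sides.

Compound 4 `Cc1ccc2[nH]c(=O)c(CN(Cc3ccc(C(C)(C)C)cc3)C(C)c3ccc(N(C)C)c(Cl)c3)cc2c1` differs from compound 3 in one place: 1-(3-chloro-4-(dimethylamino)phenyl)ethyl in place of 4-cyanobenzyl on an amine nitrogen. Within the data shown here, the three measured steps each exchange a single group on an aromatic carbon, whereas this change replaces the whole arm on the amine nitrogen, so they bear on it only loosely; and since none of them has a readable size, no size of step in this assay can be derived from them, in either direction. Among the measured compounds shown here, what the three compounds do show is that every value so far sits at a limit. Compound 4 is expected to give 10000 nM in this assay, with an estimated range of 4000 nM to 30000 nM, most likely reported once more as a limit. The step from compound 3 implied by this estimate, a step that the limit leaves unreadable from compound 3 to compound 4, is expected to be no more than scatter.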

Compound 4, half-maximal cytotoxic concentration: 9800 nM
For compound 4 the middle estimate is 1.0-fold (0.01 log units) above the measured one; the measured number falls inside the stated range.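

In this assay compound 4 gives 9800 nM, the only value in the series shown that is a number and not a limit, so the amine nitrogen can carry 1-(3-chloro-4-(dimethylamino)phenyl)ethyl and still give a measurable half-maximal cytotoxic concentration. The one step with a readable floor is an at least 1.0-fold lower number from compound 1 to compound 4 (0.00 log units; that floor lies within the scatter); on that floor alone, replacing the whole arm on this nitrogen is not shown to move the value beyond the scatter. The steps to compound 4 from compound 2 and from compound 3 cannot be read, and those two compounds give only a limit: the limit of > 5000 nM in this assay, at which 2 of the 4 values shown sit.

The series leaves open whether the chlorine, the dimethylamino group or the branched ethyl link accounts for a number appearing in place of a limit, as no compound shown separates these parts of the arm. It also leaves open whether an arm on this nitrogen carrying a carboxylic acid or a morpholine would give a number or a limit in this assay.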